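Pyridazinone thioamides: methyl for thiophen-2-yl

A few compounds are considered here, and "the series" means these few. Any claim that something is new, unique, unknown or untested is made for them only; others in the source may bear on it.

Measured so far:
compound 1 `CC/N=C(\S)CCn1nc(-c2ccccc2)ccc1=O` — 100 mg/kg
compound 2 `Cc1ccc(=S)n(CCC(=N)S)n1` — 100 mg/kg
compound 3 `N=C(S)CCn1nc(-c2cccs2)ccc1=O` — 100 mg/kg

In a functional assay on the whole organism (stomach) with Rattus norvegicus as the target (on this read-out lower numbers stand for an effect already at smaller amounts and higher numbers for an effect only at larger amounts of compound), compound 1 gives 100 mg/kg, compound 2 gives 100 mg/kg and compound 3 gives 100 mg/kg. The three values coincide at the digits shown, so compound 3 stands level with compound 1 and compound 2; no ordering among them can be read from these numbers.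

The next compound, compound 4 `Cc1ccc(=O)n(CCC(=N)S)n1`, is not yet measured. It differs from compound 3 in one place: methyl in place of thiophen-2-yl on an aromatic carbon. Compound 4 shares the thioamide chain with compound 2, and differs from it only in the ring substituent; compound 2 gives 100 mg/kg, which suggests that this kind of ring change leaves the read-out where it is.

Within the data shown here, no step between measured compounds is available as a guide, so the expectation rests on the three coincident values. The expected step in this assay is none beyond the scatter, no change at the digits printed from compound 3 to compound 4 (within the scatter). For compound 4 the estimate is 100 mg/kg, with a range from 50 mg/kg to 200 mg/kg.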

Compound 4, dose for half-maximal effect: 43.2 mg/kg
Estimate against measurement, compound 4: 2.3-fold (0.36 log units) above; the measured number lies below the stated range.
By their numbers in this assay, from the lowest: compound 4; then compounds 1, 2 and 3 (each within the scatter of the next).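

In this assay, this aromatic carbon gives the series its first readable step: methyl in place of thiophen-2-yl gives a 2.3-fold lower number from compound 3 to compound 4 (0.36 log units; beyond the scatter), so the five-membered aromatic ring is not needed at this position for an effect on this read-out. The methyl group alone does not set the value, since compound 2, which has the same methyl and thioamide chain but a thiocarbonyl in place of the ring carbonyl, gives 100 mg/kg, while compound 4 gives 43.2 mg/kg. The data shown offer no measurement that explains the step.

The compounds shown leave open whether the trend follows group size, as a single step cannot separate size from the loss of the ring. From the compounds shown here alone, whether an ethyl group, a longer alkyl chain or an amine at this position would give a lower or higher number also remains open.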